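The compounds below may be only part of what the source reports. "The series", "measured", "known", "first", "only" and "open" are said of these compounds alone.

Measured so far:
Compound 1 `O=C(O)c1ccc(-c2ccc(Cl)cc2COc2ccc(-c3nc4cc(C(=O)O)ccc4n3C3CCCCC3)cc2)cc1`: > 50000 nM (a limit)
Compound 2 `NC(=O)c1ccc(-c2ccc(Cl)cc2COc2ccc(-c3nc4cc(C(=O)O)ccc4n3C3CCCCC3)cc2)cc1`: > 50000 nM (a limit)

Both results come from a functional assay on Huh-5-2 cells (Homo sapiens), read by MTT assay (on this read-out higher numbers stand for lower toxicity in this test and lower numbers for higher toxicity in this test), where neither compound gave an exact number. Compound 2 stands at the limit of the test, with > 50000 nM recorded. The picture so far is simple: the limit of > 50000 nM in this assay, at which 2 of the 2 values shown sit. Going by the values given here, the only measured step, a step that the two limits leave unreadable from compound 1 to compound 2, therefore gives no size to build on.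

Compound 3 `O=C(O)c1ccc2c(c1)nc(-c1ccc(OCc3cc(Cl)ccc3-c3cccc(Cl)c3)cc1)n2C1CCCCC1` differs from compound 2 in one place, with 3-chlorophenyl in place of 4-carbamoylphenyl on an aromatic carbon. Among the compounds with values here, no measured step covers a change of this kind, so any forecast is loose. The expectation rests on (the limit of > 50000 nM in this assay, at which 2 of the 2 values shown sit), which points to little or no change in this assay, with some chance of a lower number, meaning higher toxicity. The estimated change is an at least 1.1-fold lower number from compound 2 to compound 3 (0.04 log units; that floor lies within the scatter). For compound 3 the expected value is 45000 nM, with an estimated range of 18000 nM to 90000 nM, and the test may again report only a limit.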

Compound 3, half-maximal cytotoxic concentration: 32000 nM
The estimate for compound 3 lay 1.4-fold (0.15 log units) above the measured number, and the stated range covers the measured number.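

With 3-chlorophenyl on this aromatic carbon, compound 3 is the first compound shown to give an exact number in this assay, so this position can change the read-out enough to leave the limit of the test. The exchange can now be given a lower bound on its size, both as an at least 1.5-fold lower number from compound 2 to compound 3 (0.19 log units; that floor lies within the scatter) and as an at least 1.5-fold lower number from compound 1 to compound 3 (0.19 log units; that floor lies within the scatter). Those floors are small, and the real gaps may be larger, but 4-carbamoylphenyl and 4-carboxyphenyl at this place have so far given only limits, whereas 3-chlorophenyl has given a number, and the limit still marks most of the series: the limit of > 50000 nM in this assay, at which 2 of the 3 values shown sit.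

The compounds shown leave open how far above the test's limit compound 1 and compound 2 truly lie, and so how large the change really is. They also leave open what a 4-chlorophenyl or a plain phenyl would give at this place, so the chlorine itself cannot yet be separated from its place on the ring or from the loss of the carbonyl-bearing group.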